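Dropping the Methyl of Compound 1: What to Expect

This account rests on a few compounds, and the source may have more. Where it says the series, first, only, none or still open, it means among the compounds named here.

In a functional assay on HeLa cells (Homo sapiens) for inhibition (on this read-out lower numbers stand for stronger inhibition and higher numbers for weaker inhibition), compound 1 `Cc1cn([C@H]2C[C@H](O)[C@@H](CO)O2)c(=O)n(/C=C/C=O)c1=O` gives 500 nM, the lowest of the three numbers at hand. Compound 2 `Cc1cn([C@@H]2O[C@H](CO)[C@@H](O)[C@@H]2O)c(=O)n(/C=C/C=O)c1=O` gives 40000 nM, and compound 3 `Cc1cn([C@H]2C[C@H](O)[C@@H](CO)O2)c(=O)n(/C=C/CO)c1=O` gives 5000 nM. The step of an 80-fold higher number from compound 1 to compound 2 (1.90 log units; beyond the scatter) and the step of a 10-fold higher number from compound 1 to compound 3 (1.00 log units; beyond the scatter) both weaken inhibition. Compound 4 `O=C/C=C/n1c(=O)ccn([C@H]2C[C@H](O)[C@@H](CO)O2)c1=O` differs from compound 1 by hydrogen in place of methyl on an aromatic carbon. Among the measured compounds shown here, neither measured step touches this aromatic carbon of the shared core: one alters the saturated ring, the other the 2-formylethenyl chain, so no measured step bears directly on the change, and the 2-formylethenyl group itself stays in place. For compound 4 a small step is therefore expected, at most slightly weaker, amounting to an estimated 2.0-fold higher number from compound 1 to compound 4 (0.30 log units; within the scatter). The estimated value for compound 4 is 1000 nM, with an expected range from 300 nM to 5000 nM.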

Compound 4, half-maximal inhibitory concentration: 800 nM
Compound 4: the middle estimate sits 1.3-fold (0.10 log units) above what was measured, within the range that was stated.
By their numbers in this assay, from the lowest: compounds 1 and 4 (each within the scatter of the next); then compound 3; then compound 2.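

Hydrogen in place of methyl on this aromatic carbon gives a 1.6-fold higher number from compound 1 to compound 4 (0.20 log units; within the scatter) and so stays within the scatter in this assay, unlike the earlier steps at the saturated ring and the 2-formylethenyl chain. Inhibition at the level of compound 1 therefore does not depend on this methyl. No measured evidence is available to explain this result.

The compounds shown carry only methyl or hydrogen at this aromatic carbon, leaving open how an ethyl group, a chlorine or an amine would fare there. They also leave open whether removing the methyl would give a similar result alongside the hydroxymethyl chain of compound 3 or the saturated ring of compound 2.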